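The source may report more compounds than this note shows. Statements on the series, on what has been measured and on what is new or still open speak of the compounds shown alone.

Compound 1 `COC(=O)Cc1c[nH]c(=O)c2ccc(Br)n12`: 165000 nM
Compound 2 `COC(=O)Cc1c[nH]c(=O)c2cc(Br)c(Br)n12`: > 200000 nM, a limit of the assay

Among the compounds with values here, in a functional assay on A549 cells (Homo sapiens) for cytotoxicity, read by CCK-8 assay, with a stated time of 72 h (on this read-out higher numbers stand for weaker inhibition and lower numbers for stronger inhibition), compound 1 gives 165000 nM, the only true number in this small set. Compound 2 returns only a limit, > 200000 nM, and that is the limit of > 200000 nM in this assay, at which 1 of the 2 values shown sits.

Compound 3 `COC(=O)Cc1c[nH]c(=O)c2cccn12` has not yet been measured in this assay. It differs from compound 1 as follows: hydrogen in place of bromo on an aromatic carbon. In words, it carries hydrogen in place of bromo on an aromatic carbon.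

Within the data shown here, only one measured step bears on this change, the one leading to compound 2: an at least 1.2-fold higher number from compound 1 to compound 2 (0.08 log units; that floor lies within the scatter). That step adds a bromo at another carbon, in the opposite sense, so it is only a loose guide. Among the measured compounds shown here, it shows no size of effect beyond the scatter, and it is the sole evidence available on bromo at this core. No step beyond the scatter is therefore expected, in either direction. The expected change is a 1.2-fold higher number from compound 1 to compound 3 (0.06 log units; within the scatter).

For compound 3 the estimated value is 190000 nM, with an expected range from 90000 nM to 400000 nM.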

Compound 3, half-maximal inhibitory concentration: > 200000 nM
Compound 3 gave a limit, no number; the forecaster's own chance of this, stated with the estimate: 45%; middle value at least 1.0-fold (0.02 log units) away from the limit.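

With hydrogen in place of bromo on the aromatic carbon next to the ring nitrogen, this assay shows an at least 1.2-fold higher number from compound 1 to compound 3 (0.08 log units; that floor lies within the scatter). Within the data shown here, the earlier step only added a second bromo, whereas this one removes the sole bromo of compound 1, and neither step can be read as a change beyond the scatter. Compound 3 returns a limit, as compound 2 does, so the true size of this step and any order between these two compounds remain unknown, and the set now rests largely on that limit: the limit of > 200000 nM in this assay, at which 2 of the 3 values shown sit.

The compounds shown leave open whether the bromo of compound 1 contributes anything at all to its value of 165000 nM. The step that removes this bromo has no measured size. They also leave open whether another group on this same carbon, such as an amine or a carboxylic acid, would give a true number in this assay and a step beyond the scatter from compound 1.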